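Urea Series: Swapping the Aryl Group on the Cyclopentane

The compounds below may be only part of what the source reports. "The series", "measured", "known", "first", "only" and "open" are said of these compounds alone.

Compound 2 `CC(C)c1cccc(C(C)C)c1NC(=O)NCC1(c2cccc(N)c2)CCCC1` gives 21 nM in an assay on microsomes for inhibition of acyl-CoA:cholesterol acyltransferase (Oryctolagus cuniculus); on this read-out higher numbers stand for weaker inhibition and lower numbers for stronger inhibition. Compound 1 `CC(C)c1cccc(C(C)C)c1NC(=O)NCC1(c2ccc(F)cc2)CCCC1` gives 23 nM in this assay; the two numbers lie within the scatter of each other, as the step of a 1.1-fold lower number from compound 1 to compound 2 (0.04 log units; within the scatter) shows, so neither compound can be set apart from the other on this read-out.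

Compound 3 `CC(C)c1cccc(C(C)C)c1NC(=O)NCC1(c2ccc(NCCO)cc2)CCCC1` has not yet been measured. It differs from compound 2 in one place: 4-((2-hydroxyethyl)amino)phenyl in place of 3-aminophenyl on a saturated ring carbon. Among the compounds with values here, only one measured step bears on this kind of change, the exchange of one aryl group for another on the same saturated ring carbon, a 1.1-fold lower number from compound 1 to compound 2 (0.04 log units; within the scatter), which left the number essentially where it was. That single step gives no sign that changing the aryl substituent moves this read-out, and nothing measured speaks to the hydroxyethylamino group itself. Compound 3 is therefore expected to show a step of a 1.2-fold higher number from compound 2 to compound 3 (0.08 log units; within the scatter), not beyond the scatter. The estimate for compound 3 in this assay is 25 nM, with a range from 9 nM to 70 nM.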

Compound 3, half-maximal inhibitory concentration: 25 nM
Estimate against measurement, compound 3: no gap at the digits printed; the range from low to high includes it.
By their numbers in this assay, from the lowest: compounds 2, 1 and 3 (each within the scatter of the next).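

In this assay, the step of a 1.2-fold higher number from compound 2 to compound 3 (0.08 log units; within the scatter) extends what the earlier pair showed: 4-((2-hydroxyethyl)amino)phenyl, with 10 heavy atoms, an oxygen, 2 hydrogen-bond donors and 2 hydrogen-bond acceptors, can stand on this saturated ring carbon with a number that cannot be told from that of 3-aminophenyl, with 7 heavy atoms. The cleaner single-place comparison, (2-hydroxyethyl)amino in place of fluoro on an aromatic carbon, gives a 1.1-fold higher number from compound 1 to compound 3 (0.04 log units; within the scatter), so this exchange also stays within the scatter, and none of the three compounds goes against a flat read-out across these aryl groups. No measurement shown offers an explanation for this flatness.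

The compounds shown leave open whether a carboxylic acid, a dimethylamino group or a longer chain such as 4-hydroxybutylamino on the phenyl ring would also keep the number within the scatter. They also leave open whether the ring location of a substituent matters, since the amine of compound 2 and the (2-hydroxyethyl)amino group of compound 3 differ both in group and in location on the phenyl ring.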